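Isopropyl to phenyl on a shared core

The source may report more compounds than this note shows. Statements on the series, on what has been measured and on what is new or still open speak of the compounds shown alone.

Measured so far in an ADME assay on Caco-2 cells (Homo sapiens) for permeability; on this read-out higher numbers stand for higher permeability and lower numbers for lower permeability:
Compound 1 `CC(C)(C)c1ccc(/C=C/C(=O)N[C@@H]2O[C@H](CO)[C@@H](O)[C@H](O)[C@H]2O)cc1`: 87.7 nm/s
Compound 2 `CC(C)c1ccc(/C=C/C(=O)N[C@@H]2O[C@H](CO)[C@@H](O)[C@H](O)[C@H]2O)cc1`: 98.5 nm/s

Among the measured compounds shown here, compound 2 stands level with compound 1, the only other measured compound. Their two values lie within the scatter of each other, so neither can be ranked above the other.

The next compound, compound 3 `O=C(/C=C/c1ccc(-c2ccccc2)cc1)N[C@@H]1O[C@H](CO)[C@@H](O)[C@H](O)[C@H]1O`, keeps the shared core and changes one group: phenyl in place of isopropyl on an aromatic carbon. This puts phenyl in place of isopropyl on an aromatic carbon, para to a large group.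

For the measured compounds named here, the one measured step that bears on this is a 1.1-fold higher number from compound 1 to compound 2 (0.05 log units; within the scatter), with hydrogen in place of methyl on a saturated chain carbon. Going by the values given here, that step is small, but it is only a weak guide, as no measured step brings in a ring. The evidence therefore points to no clear direction in this assay, and no change beyond the scatter is expected.

The expected size of the change is a 1.2-fold lower number from compound 2 to compound 3 (0.09 log units; within the scatter). For compound 3 the estimated value is 80 nm/s, with an expected range of 35 nm/s to 170 nm/s.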

Compound 3, apparent permeability: 80.2 nm/s
Beside the measured number, compound 3's estimate is 1.0-fold (0.00 log units) below it; the measured number falls inside the stated range.
By their numbers in this assay, from the lowest: compounds 3, 1 and 2 (each within the scatter of the next).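

In this assay, putting phenyl in place of isopropyl on this aromatic carbon, para to a large group, gives a 1.2-fold lower number from compound 2 to compound 3 (0.09 log units; within the scatter), while phenyl in place of tert-butyl gives a 1.1-fold lower number from compound 1 to compound 3 (0.04 log units; within the scatter) and so also stays inside the usual scatter. The earlier pair differed only in a saturated chain, so it said nothing about a ring at this position. Now a six-membered aromatic ring of carbon only has entered there, and all three compounds stand level, with no sign that this swap moves the read-out; nothing measured here offers a reason for that.

On these data alone, the groups compared at this aromatic carbon are all made of carbon alone, so it remains open whether an amine, a carboxylic acid or a longer chain in the same place would stay level with them in this assay or move beyond the scatter. Every compound also carries the shared core unchanged, which leaves open how much a change within that core would matter on this read-out.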